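The source may report more compounds than this note shows. Statements on the series, on what has been measured and on what is new or still open speak of the compounds shown alone.

Measured so far:
- compound 1 `CN1CCN(S(=O)(=O)c2ccc(NC(=O)c3ccccc3)c3ccccc23)CC1`: in an assay on L1.2 cells for binding affinity to C-C chemokine receptor type 8 (Homo sapiens) (on this read-out higher numbers stand for weaker inhibition and lower numbers for stronger inhibition), compound 1 reaches only the assay limit > 30000 nM, a limit rather than a number.
- compound 2 `CCOC(=O)N1CCC(NS(=O)(=O)c2ccc(OC(=O)c3ccccc3)c3ccccc23)CC1`: in this assay compound 2 gives 16.4 nM.
- compound 3 `Cc1ccccc1C(=O)Nc1ccc(S(=O)(=O)NC2CCN(C(=O)CCN)CC2)c2ccccc12`: in this assay compound 3 gives 11.3 nM.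

Compound 3 holds the lowest of the two numbers, but its gap to compound 2 falls within the scatter, so the two cannot be ordered. Within the data shown here, no step between measured compounds differs in one place, so nothing here calibrates the change to compound 4 `Cc1ccccc1C(=O)Nc1ccc(S(=O)(=O)NC2CCN(C(=O)N3CCC3)CC2)c2ccccc12`: azetidin-1-yl in place of 2-aminoethyl on a carbonyl carbon. The 2-aminoethyl group with its one hydrogen-bond donor and one acceptor leaves; the azetidin-1-yl ring brings neither. Without a comparable step, the expectation in this assay is a small to moderate move toward weaker inhibition, though a step not beyond the scatter would not surprise. Compound 4 is estimated at 25 nM, range 6 nM to 100 nM, meaning an expected step of a 2.2-fold higher number from compound 3 to compound 4 (0.34 log units; beyond the scatter).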

Compound 4, inhibition constant: 3.5 nM
Beside the measured number, compound 4's estimate is 7.1-fold (0.85 log units) above it, and the stated range ends above it.
By their numbers in this assay, from the lowest: compound 4; then compounds 3 and 2 (each within the scatter of the next). At a limit, above all of these: compound 1.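

On a carbonyl carbon, azetidin-1-yl in place of 2-aminoethyl gives, in this assay, a 3.2-fold lower number from compound 3 to compound 4 (0.51 log units; beyond the scatter). Among these compounds, this is the first one-place step, and it shows that a low number at this position does not depend on the 2-aminoethyl group and its hydrogen-bond donor. No measurement shown accounts for the size of this step.

Going by these compounds, whether the step follows from the four-membered ring or from the removal of the primary amine stays open. A pyrrolidin-1-yl ring or a dimethylamino group on the same carbonyl carbon would bear on that question.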